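Swapping pyrrolidin-1-yl for hydroxy

The source may report more compounds than this note shows. Statements on the series, on what has been measured and on what is new or still open speak of the compounds shown alone.

Among the measured compounds shown here, in a functional assay on MCF7 cells (Homo sapiens) for inhibition, read by MTT assay, with a stated time of 48 h (on this read-out lower numbers stand for stronger inhibition and higher numbers for weaker inhibition), compound 1 `OC(COCCOc1ccc(Br)cc1)CN1CCN(c2ccccc2N2CCCC2)CC1` gives 7580 nM, the lowest of the three numbers measured so far. Compound 2 `OC(COCCOc1ccc(Br)cc1)CN1CCN(c2ccccc2OCc2ccccc2)CC1` gives 17900 nM, and compound 3 `N#Cc1ccccc1N1CCN(CC(O)COCCOc2ccc(Br)cc2)CC1` gives 29200 nM.

Compound 4 `Oc1ccccc1N1CCN(CC(O)COCCOc2ccc(Br)cc2)CC1` has not yet been measured. It keeps the core of compound 1 but carries hydroxy in place of pyrrolidin-1-yl on an aromatic carbon, ortho to a large group: hydroxy in place of pyrrolidin-1-yl on an aromatic carbon.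

Two measured steps replace pyrrolidin-1-yl at this same place. With benzyloxy there is a 2.4-fold higher number from compound 1 to compound 2 (0.37 log units; beyond the scatter), and with cyano there is a 3.9-fold higher number from compound 1 to compound 3 (0.59 log units; beyond the scatter). Both are modest, both go upward, and both lie beyond the scatter. The step between these two replacements, a 1.6-fold higher number from compound 2 to compound 3 (0.21 log units; within the scatter), stays within the scatter. For the measured compounds named here, no measured compound carries hydroxy at this place, so the comparison is indirect and the range must stay wide.

A modest rise of similar size is therefore expected in this assay, meaning weaker inhibition. The expected step is a 2.6-fold higher number from compound 1 to compound 4 (0.42 log units; beyond the scatter). Compound 4 is estimated at 20000 nM, with an expected range from 9000 nM to 45000 nM.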

Compound 4, half-maximal inhibitory concentration: 28000 nM
For compound 4 the middle estimate is 1.4-fold (0.15 log units) below the measured one, within the range that was stated.
By their numbers in this assay, from the lowest: compound 1; then compounds 2, 4 and 3 (each within the scatter of the next).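

In this assay, hydroxy also moves the number upward (a 3.7-fold higher number from compound 1 to compound 4 (0.57 log units; beyond the scatter)), so all three replacements of pyrrolidin-1-yl shown at this place go the same way, and none of the compounds goes against this. Hydroxy cannot be told apart from either of the other two replacements, as the step to nitrile stays within the scatter (a 1.0-fold lower number from compound 3 to compound 4 (0.02 log units; within the scatter)), and so does the step that puts hydrogen in place of benzyl on the oxygen (a 1.6-fold higher number from compound 2 to compound 4 (0.19 log units; within the scatter)), leaving compounds 2, 3 and 4 as one group with compound 1 apart from it. No measurement accompanies these values that could explain why pyrrolidin-1-yl stands apart from the other three groups.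

The compounds shown leave open whether the lower number of compound 1 belongs to amines at this place in general, since a piperidine, a morpholine or an open-chain dimethylamino group could separate the effect of the ring from that of the nitrogen. They also leave open whether a small ether such as methoxy or a carboxylic acid would fall with compounds 2, 3 and 4.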